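The source may report more compounds than this note shows. Statements on the series, on what has been measured and on what is new or still open speak of the compounds shown alone.

Measured in an ADME assay on MDCK cells (Canis lupus familiaris) for cytotoxicity; on this read-out higher numbers stand for lower toxicity in this test and lower numbers for higher toxicity in this test:
- Compound 1 `CCN(CC)CN1C(=O)/C(=N/NC(N)=S)c2cc(Cl)ccc21`: 78300 nM
- Compound 2 `CCN(CC)CN1C(=O)/C(=N/NC(=S)Nc2ccc(OC)cc2)c2ccccc21`: 9200 nM

Of these two numbers, compound 2 holds the lower at 9200 nM, and its gap to compound 1 lies beyond the usual scatter. The two compounds differ in more than one place, so that gap does not isolate any single change.

Compound 3 `CCN(CC)CN1C(=O)/C(=N/NC(=S)Nc2ccc(OC)cc2)c2cc(Cl)ccc21` is compound 2 with one change, chloro in place of hydrogen on an aromatic carbon. For the measured compounds named here, no measured pair shows this change alone. Compound 1 also carries chloro, but its value of 78300 nM cannot separate that group from the other differences. No step beyond the scatter is therefore expected in this assay. The expected step, a 1.2-fold lower number from compound 2 to compound 3 (0.06 log units; within the scatter), is only an estimate. For compound 3 the estimated value is 8000 nM, with an expected range from 3000 nM to 22000 nM.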

Compound 3, half-maximal cytotoxic concentration: 11100 nM
For compound 3 the middle estimate is 1.4-fold (0.14 log units) below the measured one; low and high end bracket the measured number.
By their numbers in this assay, from the lowest: compounds 2 and 3 (each within the scatter of the next); then compound 1.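

In this assay, chloro in place of hydrogen on an aromatic carbon of the fused system gives a 1.2-fold higher number from compound 2 to compound 3 (0.08 log units; within the scatter), so this change alone leaves the read-out within the scatter when the 4-methoxyphenyl group is present. For the compounds shown here, with chloro held constant, 4-methoxyphenyl in place of hydrogen on the amide-type nitrogen gives a 7.1-fold lower number from compound 1 to compound 3 (0.85 log units; beyond the scatter), which ties a step beyond the scatter to this single change, something the two-place gap between the earlier compounds could not do. No measured evidence accounts for either step.

From the compounds shown here alone, it remains open whether chloro would give a similar result on a compound with the amide-type hydrogen still in place. Going by these compounds, it also remains open whether fluoro or a nitro group at the ring position, or an unsubstituted phenyl on the nitrogen, would give a similar result.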